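A dimethylamino-for-chloro swap on a cytotoxicity readout

This account rests on a few compounds, and the source may have more. Where it says the series, first, only, none or still open, it means among the compounds named here.

Compound 3 `CCOC(=O)c1c(-c2ccc(Cl)cc2)c(C#N)c(=O)n(/N=C(\C)c2ccc(NS(=O)(=O)c3ccc(Cl)cc3)cc2)c1N` gives 20200 nM in a functional assay on HepG2 cells (Homo sapiens) for cytotoxicity, read by sulforhodamine B assay, with a stated time of 48 h (a higher number here means a weaker inhibitor, a lower number a stronger inhibitor), the highest of the three numbers, though within the scatter of both of the others. Compound 1 `CCOC(=O)c1c(-c2ccco2)c(C#N)c(=O)n(/N=C(\C)c2ccc(NS(=O)(=O)c3ccc(Cl)cc3)cc2)c1N` gives 10300 nM and compound 2 `CCOC(=O)c1c(/C=C/c2ccccc2)c(C#N)c(=O)n(/N=C(\C)c2ccc(NS(=O)(=O)c3ccc(Cl)cc3)cc2)c1N` gives 10700 nM in this assay. All measured steps vary the same aromatic carbon: a 2.0-fold higher number from compound 1 to compound 3 (0.29 log units; within the scatter), a 1.9-fold higher number from compound 2 to compound 3 (0.28 log units; within the scatter) and a 1.0-fold higher number from compound 1 to compound 2 (0.02 log units; within the scatter), none beyond the scatter. Compound 4 `CCOC(=O)c1c(-c2ccc(N(C)C)cc2)c(C#N)c(=O)n(/N=C(\C)c2ccc(NS(=O)(=O)c3ccc(Cl)cc3)cc2)c1N` carries dimethylamino in place of chloro on an aromatic carbon, again at that carbon. Three different groups there left this assay essentially unmoved, so the step of a 1.3-fold lower number from compound 3 to compound 4 (0.13 log units; within the scatter) is expected to be small as well, with no direction beyond the scatter. Compound 4 is therefore estimated at 15000 nM in this assay, with a range from 6000 nM to 40000 nM.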

Compound 4, half-maximal inhibitory concentration: 21000 nM
The estimate for compound 4 lay 1.4-fold (0.15 log units) below the measured number; low and high end bracket the measured number.
By their numbers in this assay, from the lowest: compounds 1, 2, 3 and 4 (each within the scatter of the next, the first and the last beyond it).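

In this assay the swap of chloro for dimethylamino gives a 1.0-fold higher number from compound 3 to compound 4 (0.02 log units; within the scatter) and stays within the scatter, so a group of more heavy atoms with a hydrogen-bond acceptor is tolerated at this carbon. Within the data shown here, measured against furan-2-yl, 4-(dimethylamino)phenyl gives a 2.0-fold higher number from compound 1 to compound 4 (0.31 log units; beyond the scatter) as the first modest step here beyond the scatter, while a 2.0-fold higher number from compound 2 to compound 4 (0.29 log units; within the scatter) against 2-phenylethenyl stays within it. No supporting data bear on why this position responds so little.

On these data alone, whether a primary amine or a carboxylic acid at this carbon would move the number remains open.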